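The source may hold more compounds than are shown below. What is called first, only, known or untested is meant among the compounds shown, and "the series" means these compounds.

Working notes on the series. In an ADME assay on THP-1 cells (Homo sapiens) for cytotoxicity, read by flow cytometry and propidium iodide staining, with a stated time of 72 h (on this read-out lower numbers stand for stronger inhibition and higher numbers for weaker inhibition), compound 1 `CC(=O)Nc1ccc2oc(-c3ccccc3)c(O)c(=O)c2c1` gives 36000 nM. Compound 2 `CC(=O)Nc1ccc2oc(-c3cccc(F)c3)c(O)c(=O)c2c1` stands level with it, with compound 2 at 36000 nM. The next structure, compound 3 `CC(=O)Nc1ccc2oc(-c3cccc(C(F)(F)F)c3)c(O)c(=O)c2c1`, is not yet measured. It differs from compound 2 as follows: trifluoromethyl in place of fluoro on an aromatic carbon. In words, this is trifluoromethyl in place of fluoro on an aromatic carbon, meta to a large group. Going by the values given here, only one measured step bears on this change, the fluoro in place of hydrogen on an aromatic carbon, and it shows no change at the digits printed from compound 1 to compound 2 (within the scatter). Among the compounds with values here, no measured compound carries trifluoromethyl, so the evidence is thin. Within the data shown here, with no change at the digits printed from compound 1 to compound 2 (within the scatter) as the only guide, a step within the scatter is expected in this assay, with no firm direction. The estimated step is a 1.1-fold lower number from compound 2 to compound 3 (0.05 log units; within the scatter). For compound 3 the expected value is 32000 nM, with an estimated range of 15000 nM to 65000 nM.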

Compound 3, half-maximal inhibitory concentration: 1000 nM
Beside the measured number, compound 3's estimate is 32-fold (1.51 log units) above it; the whole stated range lies above it.
By their numbers in this assay, from the lowest: compound 3; then compounds 1 and 2 (each within the scatter of the next).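

In this assay, this place on the six-membered aromatic ring of carbon only proves sensitive to the group it carries, which the fluoro step alone did not show: trifluoromethyl gives a 36-fold lower number from compound 2 to compound 3 (1.56 log units; beyond the scatter), a change far larger than no change at the digits printed from compound 1 to compound 2 (within the scatter). Measured against hydrogen, trifluoromethyl gives a 36-fold lower number from compound 1 to compound 3 (1.56 log units; beyond the scatter), so the read-out separates trifluoromethyl from both hydrogen and fluoro, and those two stand level. Nothing available explains why the larger group gives this step.

From the compounds shown here alone, it remains open whether a methyl, chloro or methoxy group at this same place would stand with trifluoromethyl or with fluoro. Also open, going by these compounds, is whether trifluoromethyl would give a step of similar size at another carbon of the same ring.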